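Chloro to Fluoro on the Amide-Bearing Ring: Solubility Outlook

The source may hold more compounds than are shown below. What is called first, only, known or untested is meant among the compounds shown, and "the series" means these compounds.

Compound 1, `CCCS(=O)(=O)Nc1ccc(Cl)c(C(=O)Nc2cnc3[nH]nc(OC)c3c2)c1F`: 2 ug/mL
Compound 2, `CCCS(=O)(=O)Nc1ccc(F)c(C(=O)Nc2cnc3[nH]cc(Br)c3c2)c1F`: a limit, < 1 ug/mL

Going by the values given here, in a physicochemical assay for solubility, read by HPLC, in phosphate buffer, with a stated time of 24 h, at pH 7.4 (a higher number here means a more soluble compound, a lower number a less soluble compound), compound 1 gives 2 ug/mL, the only number in the set. The reading for compound 2 is the limit of < 1 ug/mL in this assay, at which 1 of the 2 values shown sits, not a number. Compound 3, `CCCS(=O)(=O)Nc1ccc(F)c(C(=O)Nc2cnc3[nH]nc(OC)c3c2)c1F`, has not yet been measured; it differs from compound 1 by fluoro in place of chloro on an aromatic carbon. Among the compounds with values here, no measured step exists between the two measured compounds, so the expectation rests on compound 1 alone. The change is expected to be small, a 1.5-fold higher number from compound 1 to compound 3 (0.18 log units; within the scatter), with no direction beyond the usual scatter. Compound 3 is estimated to give 3 ug/mL, with a range from 1 ug/mL to 8 ug/mL.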

Compound 3, solubility: 9 ug/mL
Compound 3: the middle estimate sits 3.0-fold (0.48 log units) below what was measured; the measured number lies above the stated range.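

In this assay, fluoro in place of chloro on the aromatic carbon para to the (propylsulfonyl)amino group gives a 4.5-fold higher number from compound 1 to compound 3 (0.65 log units; beyond the scatter). Going by these compounds alone, the earlier compounds held no step at this position, so this pair is the first sign that the read-out responds to an exchange of a single atom there, and it is only one pair. Nothing shown accounts for the size of this step.

Going by these compounds, whether an amine or a nitrile on this carbon would read higher or lower than fluoro stays open. On these data alone, whether the step carries over to another core also stays open.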